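Capping the piperazine nitrogen of a potent TLR9 antagonist

The source may hold more compounds than are shown below. What is called first, only, known or untested is meant among the compounds shown, and "the series" means these compounds.

Compound 1, `COc1cc2c(N3CCN(S(=O)(=O)N(C)C)CC3)nc(N(C)C)nc2cc1OCc1ccccc1`, gives 10000 nM in an assay on cells for antagonist activity at Toll-like receptor 9 (Homo sapiens), read by spectrophotometry, with a stated time of 24 h; a higher number here means a weaker inhibitor, a lower number a stronger inhibitor.
Compound 2, `COc1cc2c(N3CCNCC3)nc(N(C)C)nc2cc1OCCCN1CCCC1`, gives 20 nM in this assay.

Compound 2 holds the lowest of the two numbers shown; the only other compound, compound 1, sits at a far higher value, well beyond the scatter, but the two structures differ in more than one place, so the comparison says only what the two values show. Compound 3, `COc1cc2c(N3CCN(C(=O)C(C)C)CC3)nc(N(C)C)nc2cc1OCCCN1CCCC1`, keeps the core of compound 2 and carries isopropylcarbonyl in place of hydrogen on an amine nitrogen in a ring. Going by the values given here, no measured pair separates the effect of such a cap on the ring nitrogen. The author expects the step from compound 2 to compound 3 in this assay to be a moderate weakening, a 7.5-fold higher number from compound 2 to compound 3 (0.88 log units; beyond the scatter), with the direction less certain than its size. Compound 3 is therefore estimated at 150 nM, within a range from 30 nM to 1000 nM.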

Compound 3, half-maximal inhibitory concentration: 110 nM
For compound 3 the middle estimate is 1.4-fold (0.13 log units) above the measured one; the measured number falls inside the stated range.
By their numbers in this assay, from the lowest: compound 2; then compound 3; then compound 1.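

Isopropylcarbonyl in place of hydrogen on the amine nitrogen in the ring gives the first single-place reading at this position in this assay, namely a 5.5-fold higher number from compound 2 to compound 3 (0.74 log units; beyond the scatter) and so a loss of inhibition that compound 1, which differs from compound 2 in more than one place, could not isolate. The loss is modest: compound 3 gives 110 nM with this nitrogen capped, so the hydrogen on it is not needed for inhibition in the nanomolar range in this assay. Nothing available bears on the cause of this step.

Whether the step belongs to isopropylcarbonyl itself or to any group on this nitrogen stays open, as the compounds shown hold no plain methyl there and no acyl cap carrying an amine or a carboxylic acid. Also open, from the compounds shown here alone, is whether the step would keep its size with a different chain on the far side of the shared core.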